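Changing the Ether Aryl Group and Cell Tolerance

The source may hold more compounds than are shown below. What is called first, only, known or untested is meant among the compounds shown, and "the series" means these compounds.

Compound 1, `N#Cc1ccc(Nc2nc(Oc3ccccc3Cl)c3ccccc3n2)cc1`, gives 38000 nM.
Compound 2, `N#Cc1ccc(Nc2nc(Oc3ccc(F)cc3)c3ccccc3n2)cc1`, gives only a limit, > 351000 nM.

In an ADME assay on MT4 cells (Homo sapiens) for cytotoxicity, read by MTT assay, with a stated time of 4 days (a higher number here means that more compound is tolerated, a lower number that less compound is tolerated), compound 1 gives 38000 nM. Compound 2 reaches only a limit of this assay, > 351000 nM, so no exact number is known for it. Going by the values given here, the single measured step, an at least 9.2-fold higher number from compound 1 to compound 2 (0.96 log units; beyond the scatter), is bounded by the limit of > 351000 nM in this assay, at which 1 of the 2 values shown sits. Compound 2 therefore stands at the better-tolerated end of the two numbers shown, with its true value unknown beyond that limit.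

Compound 3, `COc1cc(C#N)ccc1Oc1nc(Nc2ccc(C#N)cc2)nc2ccccc12`, has not yet been measured. It differs from compound 2 in one place: 4-cyano-2-methoxyphenyl in place of 4-fluorophenyl on an oxygen on an aromatic ring. The measured step of an at least 9.2-fold higher number from compound 1 to compound 2 (0.96 log units; beyond the scatter) bears on this in that both changes replace the group on the same oxygen, yet the pair of groups swapped is different, so it says little about the size or direction of the new change. With only this to go on, no step beyond the scatter is expected, and compound 3 is estimated at 200000 nM, within 40000 nM to 400000 nM. The step of an at least 1.7-fold lower number from compound 2 to compound 3 (0.24 log units; that floor lies within the scatter) is thus expected to be small, with a real chance that only a limit is recorded again.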

Compound 3, half-maximal cytotoxic concentration: >= 140000 nM
Compound 3 was reported as a limit; the forecaster's own chance of this, stated with the estimate: 55%; the middle value lies beyond the limit too.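

In this assay, placing 4-cyano-2-methoxyphenyl on this oxygen instead of 2-chlorophenyl gives an at least 3.6-fold higher number from compound 1 to compound 3 (0.56 log units; beyond the scatter), so a second group, quite different from the 4-fluorophenyl of compound 2, also stands clear of compound 1. Among these three compounds, the larger group that enters here, with its nitrile and methoxy substituents, does not bring the number back to the level of compound 1, and only compound 1, with its 2-chlorophenyl, has a value that is an exact number. Compound 3 is recorded only as a limit, and the step from compound 2 to compound 3 cannot be read, so nothing can be said about the order of these two compounds, and the reading is bounded in this way: the limit of >= 140000 nM in this assay, at which 1 of the 3 values shown sits.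

From the compounds shown here alone, it remains open how far the true values of compound 2 and compound 3 lie beyond their limits, and whether the nitrile or the methoxy of compound 3 matters more when each stands alone on the ring. Also open, going by these compounds, is whether an aryl group carrying an amine or a carboxylic acid on this oxygen would stay as well tolerated.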